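The source may report more compounds than this note shows. Statements on the series, on what has been measured and on what is new or still open speak of the compounds shown alone.

In a functional assay on MOLT-4 cells (Homo sapiens) (a lower number here means a stronger inhibitor, a higher number a weaker inhibitor), three compounds sharing one core have been measured. Compound 3 `OCc1cn([C@@H]2O[C@H](CO)[C@@H](O)[C@H]2O)nn1` carries hydroxymethyl on an aromatic carbon. Compound 3 gives > 200000 nM, which is a limit and not a number. Compound 1 `NC(=O)c1cn([C@@H]2O[C@H](CO)[C@@H](O)[C@H]2O)nn1`, which carries carbamoyl at that place, gives > 200000 nM, which is also a limit. Compound 3 thus stands at the limit of > 200000 nM in this assay, at which 2 of the 3 values shown sit, and the comparison yields a step that the two limits leave unreadable from compound 1 to compound 3. Among the compounds with values here, compound 2 `CCCCCCCCc1cn([C@@H]2O[C@H](CO)[C@@H](O)[C@H]2O)nn1`, with an octyl chain at that place, gives 50000 nM, the only true number. Its comparison yields an at least 4.0-fold higher number from compound 2 to compound 3 (0.60 log units; beyond the scatter).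

Compound 4 `OC[C@H]1O[C@@H](n2cc(-c3ccsc3)nn2)[C@H](O)[C@@H]1O` has not yet been measured. It has thiophen-3-yl in place of hydroxymethyl on an aromatic carbon of a five-membered aromatic ring with 3 nitrogen: thiophen-3-yl in place of hydroxymethyl on an aromatic carbon. Within the data shown here, the step from compound 2 is the only readable guide, since it shows an at least 4.0-fold higher number from compound 2 to compound 3 (0.60 log units; beyond the scatter). Read in reverse, it links a larger group than hydroxymethyl to a lower number. Thiophen-3-yl is a different kind of group, however, so the guide is loose. A modest move towards a lower number is expected, and the result may yet remain a limit. The expected change is an at least 2.0-fold lower number from compound 3 to compound 4 (0.30 log units; that floor lies within the scatter). For compound 4 the estimate is 100000 nM, with an expected range from 35000 nM to 200000 nM.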

Compound 4, half-maximal inhibitory concentration: 126000 nM
Estimate against measurement, compound 4: 1.3-fold (0.10 log units) below; low and high end bracket the measured number.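

In this assay, thiophen-3-yl on this aromatic carbon yields a true number, so a group with one five-membered aromatic ring and no hydrogen-bond donor moves the series off the value at which compound 1 and compound 3 sit: the limit of > 200000 nM in this assay, at which 2 of the 4 values shown sit.

Measured against hydroxymethyl, the change is an at least 1.5-fold lower number from compound 3 to compound 4 (0.20 log units; that floor lies within the scatter), and measured against carbamoyl, it is an at least 1.5-fold lower number from compound 1 to compound 4 (0.20 log units; that floor lies within the scatter). Both steps rest on limits and give only floors. Within the data shown here, they show that the octyl chain is not the only group here to give a measurable value: compound 2 gives 50000 nM, and compound 4 gives 126000 nM.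

The compounds shown leave open whether the ring or its sulfur matters, which a phenyl or furan-3-yl group at this place could separate, and whether a butyl chain or a chain longer than octyl would follow compound 2. As far as these compounds go, how an amine or a carboxylic acid on this carbon would read also remains open, and the step between the two compounds that stand at limits cannot be read.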